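From ethyl to tert-butyl on a shared core

The compounds below may be only part of what the source reports. "The series", "measured", "known", "first", "only" and "open" are said of these compounds alone.

Measured in an ADME assay on H9c2 cells (Rattus norvegicus) for cytotoxicity; a higher number here means a weaker inhibitor, a lower number a stronger inhibitor:
- Compound 1 `O=C(Nc1nc2cccc(Cl)c2s1)C1CC1`: > 50000 nM, a limit
- Compound 2 `CCc1ccc2nc(NC(=O)C3CC3)sc2c1`: > 50000 nM, a limit

In this assay compound 2 gives > 50000 nM, which is a limit of the assay and not a number. Compound 3 `CC(C)(C)c1ccc2nc(NC(=O)C3CC3)sc2c1` carries tert-butyl in place of ethyl on an aromatic carbon. Among the measured compounds shown here, no measured step shows what such a change does. For the measured compounds named here, the only guide for compound 2 and its neighbour is the limit of > 50000 nM in this assay, at which 2 of the 2 values shown sit. The step of a number no higher from compound 2 to compound 3 (the limit leaves the size open) is therefore expected to stay within the scatter in this assay, with no direction foreseen. For compound 3 the estimated value is 50000 nM, with an expected range of 20000 nM to 100000 nM.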

Compound 3, half-maximal inhibitory concentration: 32000 nM
Estimate against measurement, compound 3: 1.6-fold (0.19 log units) above; the measured number falls inside the stated range.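

Among the compounds shown here, with tert-butyl in place of ethyl on an aromatic carbon, compound 3 gives the first value in this assay that is a number and not a limit. As far as these compounds go, the change reads as an at least 1.5-fold lower number from compound 2 to compound 3 (0.19 log units; that floor lies within the scatter), and its true size stays open, as compound 2 is held only by a limit. The shared core still sits mostly at that limit: the limit of > 50000 nM in this assay, at which 2 of the 3 values shown sit.

The compounds shown leave open what an amine, a carboxylic acid or a longer chain at this position would do to the number, and whether any change here reaches beyond the scatter.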